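The compounds below may be only part of what the source reports. "The series", "measured", "known", "first", "only" and "open" are said of these compounds alone.

The series shares one core. Compound 1 `COc1ccc(-c2ccn(CCC(C)C)c(=O)c2C#N)cc1Cl`, compound 2 `CC(C)CCn1ccc(-c2ccc(OCC3CC3)c(Cl)c2)c(C#N)c1=O` and compound 3 `CC(C)CCn1ccc(-c2ccc(OC3CCCC3)c(Cl)c2)c(C#N)c1=O` differ only in the group on the aromatic oxygen. In a functional assay on CHO cells for positive allosteric modulation of metabotropic glutamate receptor 2 (Homo sapiens), read by scintillation counting and GTPgammaS binding, with a stated time of 30 min (on this read-out lower numbers stand for an effect already at smaller amounts and higher numbers for an effect only at larger amounts of compound), compound 1 gives 363 nM, compound 2 gives 110 nM and compound 3 gives 100 nM. Compound 3 carries the lowest of the three numbers, though the step of a 1.1-fold lower number from compound 2 to compound 3 (0.04 log units; within the scatter) is within the scatter, so compound 3 is not separated from compound 2. Against compound 1 the steps of a 3.3-fold lower number from compound 1 to compound 2 (0.52 log units; beyond the scatter) and a 3.6-fold lower number from compound 1 to compound 3 (0.56 log units; beyond the scatter) are both beyond the scatter.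

Compound 4 `CC(C)CCn1ccc(-c2ccc(OC3CCOCC3)c(Cl)c2)c(C#N)c1=O` is not yet measured. Its difference from compound 3: oxan-4-yl in place of cyclopentyl on an oxygen on an aromatic ring. Within the data shown here, of the measured steps, only one swaps a ring-bearing group for another on the same oxygen, and that step, a 1.1-fold lower number from compound 2 to compound 3 (0.04 log units; within the scatter), is within the scatter. Among the measured compounds shown here, the larger steps from compound 1 replace a methyl, not a ring, and no measured pair shows a hetero atom entering the ring on the oxygen. Both cyclopentyl and oxan-4-yl are single non-aromatic rings, so in this assay no step beyond the scatter is expected. Compound 4 is estimated at 150 nM, with a range from 60 nM to 400 nM. This corresponds to an expected step of a 1.5-fold higher number from compound 3 to compound 4 (0.18 log units; within the scatter).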

Compound 4, half-maximal effective concentration: 186 nM
The estimate for compound 4 lay 1.2-fold (0.09 log units) below the measured number, and the stated range covers the measured number.
By their numbers in this assay, from the lowest: compounds 3, 2, 4 and 1 (each within the scatter of the next, the first and the last beyond it).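

In this assay, oxan-4-yl brings the first hetero atom into the ring on the oxygen on the aromatic ring, and it gives a 1.9-fold higher number from compound 3 to compound 4 (0.27 log units; within the scatter) and a 1.7-fold higher number from compound 2 to compound 4 (0.23 log units; within the scatter), so this position accepts a six-membered non-aromatic ring with one hydrogen-bond acceptor in place of cyclopentyl or cyclopropylmethyl without a step beyond the scatter. Set against the methyl group of compound 1, the same change gives a 2.0-fold lower number from compound 1 to compound 4 (0.29 log units; within the scatter), so compound 4 differs from compounds 2 and 3, whose steps from compound 1 are printed as beyond the scatter. No supporting data bear on these steps, and the reason for this difference remains unexplained.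

The compounds shown leave open how this assay would read with a piperidin-4-yl ring, which has an amine nitrogen where oxan-4-yl has its ring oxygen, or with an open 2-methoxyethyl chain on the same oxygen. They also leave open whether oxan-4-yl would give similar steps if the chlorine or the chain on the shared core were replaced, for example by a fluorine or a longer chain.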